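Phthalimide Amides as Glutamate Receptor Blockers: Next Step

The compounds below may be only part of what the source reports. "The series", "measured", "known", "first", "only" and "open" are said of these compounds alone.

Three compounds share a core in which a benzamide carries a phthalimide group, and they were tested in an in vitro functional assay on HEK293-A cells for antagonist activity at metabotropic glutamate receptor 5 (Rattus norvegicus), read by calcium flux; on this read-out higher numbers stand for weaker inhibition and lower numbers for stronger inhibition. For compound 1 `COCC(=O)Nc1cccc(NC(=O)c2ccccc2OC)c1` this assay reports only a limit, > 30000 nM, rather than a number. Compound 2 `COc1cc(NC(=O)c2cccc(N3C(=O)c4ccccc4C3=O)c2)cc(OC)c1` gives 3580 nM, and compound 3 `O=C(Nc1ccccn1)c1cccc(N2C(=O)c3ccccc3C2=O)c1` gives 1260 nM, the lowest of the two numbers shown. Among the measured compounds shown here, the step of a 2.8-fold lower number from compound 2 to compound 3 (0.45 log units; beyond the scatter) is the only measured change at that amide-type nitrogen.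

Compound 4 `O=C(NC1CC2CCC1C2)c1cccc(N2C(=O)c3ccccc3C2=O)c1` differs from compound 3 at the same position: a group of 7 heavy atoms (7 carbon; 2 five-membered non-aromatic rings of carbon only) in place of a group of 6 heavy atoms (5 carbon, 1 nitrogen; one six-membered aromatic ring with 1 hetero atom), on an amide-type nitrogen. For the measured compounds named here, no measured step covers a swap of an aromatic ring for a saturated ring system, so the one step available, from compound 2 to compound 3, only shows that replacing one flat ring with another moved the number modestly. A change from a flat, aromatic group to a bulkier, non-aromatic one without any hydrogen-bond acceptor is a larger structural move, and the direction cannot be read from the data shown.

Compound 4 is therefore expected to show a modest weakening, a 2.0-fold higher number from compound 3 to compound 4 (0.30 log units; within the scatter), with an estimated value of 2500 nM in this assay, likely between 600 nM and 10000 nM.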

Compound 4, half-maximal inhibitory concentration: > 30000 nM
Compound 4 gave a limit, no number; the forecaster's own chance of this, stated with the estimate: 15%; middle value at least 12-fold (1.07 log units) from the limit.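

Among the compounds shown here, at the amide-type nitrogen, the earlier compounds showed only that one aromatic ring could replace another with a modest shift; a group with 2 five-membered non-aromatic rings of carbon only behaves very differently, giving an at least 23-fold higher number from compound 3 to compound 4 (1.37 log units; beyond the scatter). The drop also holds against the 3,5-dimethoxyphenyl group, with an at least 8.3-fold higher number from compound 2 to compound 4 (0.92 log units; beyond the scatter), so among the three compounds sharing this core, both with an aromatic ring at this position give numbers and the one without gives none. Compound 4 gives a limit rather than a number, so the full size of both steps stays unknown, and in this assay it sits with one other compound at the same limit: the limit of > 30000 nM in this assay, at which 2 of the 4 values shown sit.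

The compounds shown do not separate the loss of the aromatic ring from the loss of the ring nitrogen, and a plain phenyl, a cyclohexyl or a piperidin-4-yl group on this nitrogen would help to pull those two changes apart. Also open, on these data alone, is whether a pyridin-3-yl group, or a benzyl group that sets the ring one carbon further out, would match or improve on pyridin-2-yl.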